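The compounds below may be only part of what the source reports. "The series", "measured", "known", "first", "only" and "open" are said of these compounds alone.

Measured so far:
compound 1 `CNc1nc(Nc2ccc(C#N)cc2)nc(Oc2ccc3ccccc3c2)n1` — 250000 nM
compound 2 `N#Cc1ccc(Nc2nc(N)nc(Oc3ccc4ccccc4c3)n2)cc1` — 42200 nM
compound 3 `CC(C)Nc1nc(Nc2ccc(C#N)cc2)nc(Oc2ccc3ccccc3c2Br)n1` — 41500 nM

In an ADME assay on MT4 cells (Homo sapiens) for cytotoxicity, read by MTT assay, with a stated time of 4 days (a higher number here means that more compound is tolerated, a lower number that less compound is tolerated), compound 1 stands highest of the three; compound 2 is nearest to it and compound 3 furthest. Compound 4 `CNc1nc(Nc2ccc(C#N)cc2)nc(Oc2ccc3cc(Br)ccc3c2)n1` differs from compound 1 by bromo in place of hydrogen on an aromatic carbon. Among the measured compounds shown here, the only measured single-point step, a 5.9-fold lower number from compound 1 to compound 2 (0.77 log units; beyond the scatter), changes the amine rather than the fused two-ring system, so it does not bear directly on this change. Compound 3 carries a bromo on its fused two-ring system together with a different amine and gives a lower number than compound 1, but it alters two places at once and does not isolate the bromo. A modest fall is therefore expected, a 2.5-fold lower number from compound 1 to compound 4 (0.40 log units; beyond the scatter). Compound 4 is estimated at 100000 nM with a range of 35000 nM to 250000 nM.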

Compound 4, half-maximal cytotoxic concentration: 194000 nM
The estimate for compound 4 lay 1.9-fold (0.29 log units) below the measured number; the measured number falls inside the stated range.
By their numbers in this assay, from the lowest: compounds 3 and 2 (each within the scatter of the next); then compounds 4 and 1 (each within the scatter of the next).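

In this assay the bromo in place of hydrogen on an aromatic carbon of the fused system of two rings gives a 1.3-fold lower number from compound 1 to compound 4 (0.11 log units; within the scatter) and so leaves the number within the scatter. Unlike compound 3, which alters two places at once, this pair isolates the bromo at this position, on the methylamine core of compound 1. No measurement on hand accounts for this result. Still open, as far as these compounds go, is how an amine, a carboxylic acid or a methoxy group at this position would read, and whether the bromo behaves the same way on the core of compound 2.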